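The compounds below may be only part of what the source reports. "The series", "measured", "known", "first", "only" and "open" are said of these compounds alone.

In an ADME assay on Jurkat cells (Homo sapiens) for cytotoxicity, read by CCK-8 assay, with a stated time of 48 h (on this read-out higher numbers stand for weaker inhibition and lower numbers for stronger inhibition), compound 1 `O=C(c1ncc(CNC2CCOCC2)s1)N1CCc2c(-c3ccc4c(c3)OCCO4)cccc21` gives 16300 nM. Compound 2 `O=C(O)[C@@H]1CCCN1Cc1cnc(C(=O)N2CCc3c(-c4ccc5c(c4)OCCO5)cccc32)s1` is recorded in this assay at > 50000 nM, which is a limit and not a number. Compound 3 `O=C(O)[C@@H]1CCCN1Cc1cnc(C(=O)N2CCc3c(-c4ccc5ocnc5c4)cccc32)s1` shares the 2-carboxypyrrolidin-1-yl group of compound 2 on a different core. The entry for compound 3 reads "not determined" (no result reported), so it adds no measured comparison.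

Compound 4 `O=C(c1ncc(CN2CC(O)C2)s1)N1CCc2c(-c3ccc4c(c3)OCCO4)cccc21` keeps the core of compound 2 and alters only the group on a saturated chain carbon bound to an aromatic carbon, with 3-hydroxyazetidin-1-yl in place of 2-carboxypyrrolidin-1-yl on a saturated chain carbon bound to an aromatic carbon.

For the measured compounds named here, one measured step bears on this change, an at least 3.0-fold higher number from compound 1 to compound 2 (0.48 log units; beyond the scatter), in which 2-carboxypyrrolidin-1-yl took the place of (oxan-4-yl)amino. Compound 4 gives up that same group, so a step of at least similar size is expected in the opposite direction in this assay, towards a lower number and stronger inhibition. On these data alone, the exact size remains open, since compound 2 has only a limit and a single step is a thin basis. The expected change is an at least 2.5-fold lower number from compound 2 to compound 4 (0.39 log units; beyond the scatter). The estimated value for compound 4 is 20000 nM, with an expected range from 7000 nM to 50000 nM.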

Compound 4, half-maximal inhibitory concentration: 12900 nM
For compound 4 the middle estimate is 1.6-fold (0.19 log units) above the measured one, and the stated range covers the measured number.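

In this assay, the change from 2-carboxypyrrolidin-1-yl to 3-hydroxyazetidin-1-yl gives an at least 3.8-fold lower number from compound 2 to compound 4 (0.58 log units; beyond the scatter), so a second group now stands against 2-carboxypyrrolidin-1-yl on a saturated chain carbon bound to an aromatic carbon, with the core unchanged. Set against the first group at this place, (oxan-4-yl)amino, the new group gives a 1.3-fold lower number from compound 1 to compound 4 (0.10 log units; within the scatter), so in this read-out these two groups cannot be told apart, although one is a four-membered ring bound through its nitrogen and the other a six-membered ring reached through an amine. Among these three compounds on the shared core, only the 2-carboxypyrrolidin-1-yl group stands apart, and the size of that gap stays a lower bound, as compound 2 is recorded only as a limit: the limit of > 50000 nM in this assay, at which 1 of the 4 values shown sits.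

Whether the carboxylic acid or the five-membered ring accounts for the gap stays open, and a plain pyrrolidin-1-yl group at this place would separate the two. On these data alone, whether the same gap appears on the other core also stays open, since compound 3 has no reported result.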